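From iodo to acetylphenyl on the sulfur of a nucleoside

The compounds below may be only part of what the source reports. "The series", "measured", "known", "first", "only" and "open" are said of these compounds alone.

Compound 1, `CCCCSc1nc(N)nc2c1ncn2[C@@H]1O[C@H](CO)[C@@H](O)[C@H]1O`: 12000 nM in an assay on isolated protein for binding affinity to Equilibrative nucleoside transporter 1 (Homo sapiens); on this read-out lower numbers stand for stronger inhibition and higher numbers for weaker inhibition
Compound 2, `Nc1nc(SI)c2ncn([C@@H]3O[C@H](CO)[C@@H](O)[C@H]3O)c2n1`: 81300 nM in this assay

The two measured compounds share one core and differ only in the group carried on a sulfur. Compound 2 gives the higher of the two numbers, and the step of a 6.8-fold higher number from compound 1 to compound 2 (0.83 log units; beyond the scatter) shows a modest weakening when butyl gives way to iodo. Compound 3, `CC(=O)c1ccccc1Sc1nc(N)nc2c1ncn2[C@@H]1O[C@H](CO)[C@@H](O)[C@H]1O`, takes the change one step further: 2-acetylphenyl in place of iodo on a sulfur. Only the butyl-to-iodo step bears on this move, and it went towards weaker binding when the carbon group left the sulfur; returning a carbon group, now a ring bearing an acetyl, could undo that loss, though an acetylphenyl is not a butyl, so the expectation is loose. Compound 3 is expected to give a lower number than its parent, with the estimated step of a 14-fold lower number from compound 2 to compound 3 (1.13 log units; beyond the scatter). Compound 3 is estimated at 6000 nM. The expected range for compound 3 runs from 1200 nM to 30000 nM.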

Compound 3, half-maximal inhibitory concentration: 447000 nM
Compound 3: the middle estimate sits 75-fold (1.87 log units) below what was measured; the measured number lies above the stated range.
By their numbers in this assay, from the lowest: compound 1; then compound 2; then compound 3.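

Returning a carbon group to the sulfur does not by itself recover binding in this assay: the 2-acetylphenyl group gives a 5.5-fold higher number from compound 2 to compound 3 (0.74 log units; beyond the scatter), so it does worse here than even iodo. Measured against butyl, the same group gives a 37-fold higher number from compound 1 to compound 3 (1.57 log units; beyond the scatter), a large step, which shows that this position responds strongly to what is placed on the sulfur and that carrying carbon is not enough; among these three compounds, butyl gives the lowest number. Nothing available here explains why the change weakens binding.

These compounds cannot separate the effect of the ring from that of the acetyl, and a plain phenyl on the sulfur would address that. On these data alone, it also remains open whether a shorter chain such as methyl, or a longer one such as hexyl, would improve on butyl.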